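Urea terminus variation on the shared core: compound 4

This account rests on a few compounds, and the source may have more. Where it says the series, first, only, none or still open, it means among the compounds named here.

Measured compounds:
- compound 1, `O=C(Nc1ccc(Nc2ncnc3c2OCCN3)cc1)Nc1ccc(Cl)c(C(F)(F)F)c1`: 188 nM
- compound 2, `O=C(Nc1ccc(Cl)cc1)Nc1ccc(Nc2ncnc3c2OCCN3)cc1`: 2280 nM
- compound 3, `Cc1ccc(F)c(NC(=O)Nc2ccc(Nc3ncnc4c3OCCN4)cc2)c1`: 5110 nM

In an assay on isolated protein for inhibition of proto-oncogene tyrosine-protein kinase receptor Ret variant V804M (Homo sapiens), read by 33P incorporation, with stated times of 15 min and 40 min (a lower number here means a stronger inhibitor, a higher number a weaker inhibitor), compound 3 stands highest of the three numbers. Its nearest neighbour is compound 2, reached through a 2.2-fold higher number from compound 2 to compound 3 (0.35 log units; beyond the scatter); compound 1 lies furthest away, the two being separated by a 12-fold higher number from compound 1 to compound 2 (1.08 log units; beyond the scatter) together with that aryl swap.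

Compound 4, `CC(C)(C)c1csc(NC(=O)Nc2ccc(Nc3ncnc4c3OCCN4)cc2)n1`, is not yet measured. The change from compound 3 is 4-(tert-butyl)-1,3-thiazol-2-yl in place of 2-fluoro-5-methylphenyl on an amide-type nitrogen. Among the measured compounds shown here, no measured step covers this exchange directly. What the two steps do show is that the group on this amide-type nitrogen moves the number: a 12-fold higher number from compound 1 to compound 2 (1.08 log units; beyond the scatter) is large, a 2.2-fold higher number from compound 2 to compound 3 (0.35 log units; beyond the scatter) is modest. A step beyond the scatter is therefore expected here too, and since compound 3 already sits at the top of the series, the step is expected to run toward a lower number, with wide uncertainty. Compound 4 is estimated at 1000 nM, range 150 nM to 5000 nM, which would mean an expected 5.1-fold lower number from compound 3 to compound 4 (0.71 log units; beyond the scatter).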

Compound 4, half-maximal inhibitory concentration: 5170 nM
The estimate for compound 4 lay 5.2-fold (0.71 log units) below the measured number; the whole stated range lies below it.
By their numbers in this assay, from the lowest: compound 1; then compound 2; then compounds 3 and 4 (each within the scatter of the next).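

In this assay, replacing the six-membered carbon ring with a five-membered aromatic ring with 2 hetero atoms on the amide-type nitrogen gives a 1.0-fold higher number from compound 3 to compound 4 (0.01 log units; within the scatter), so a terminus of a different ring type and with 2 hydrogen-bond acceptors leaves the number where compound 3 put it. Against the 4-chlorophenyl terminus, the same group gives a 2.3-fold higher number from compound 2 to compound 4 (0.36 log units; beyond the scatter), a modest step of about the same size as the one to compound 3. Nothing available explains why the exchange is silent.

As far as these compounds go, it remains open whether the 1,3-thiazol-2-yl ring or the tert-butyl group sets this result, a question that a thiazole carrying trifluoromethyl or an amine in place of tert-butyl would address. Also open, from the compounds shown here alone, is whether any thiazole terminus can approach compound 1 at 188 nM.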